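The source may hold more compounds than are shown below. What is called first, only, known or untested is meant among the compounds shown, and "the series" means these compounds.

Compound 1 `c1ccc(Nc2ccc(N3CC4CC(C3)N4)nn2)cc1` gives 441 nM.
Compound 2 `Clc1ccc(Nc2cncc(N3CC4CC(C3)N4)c2)cc1` gives 0.118 nM.
Compound 3 `Clc1ccc(Nc2ccc(N3CC4CC(C3)N4)nn2)cc1Cl` gives 516 nM.

These three compounds were examined in an assay on cell membranes for displacement of a labelled ligand from Neuronal acetylcholine receptor; alpha4/beta2 (Rattus norvegicus); on this read-out higher numbers stand for weaker inhibition and lower numbers for stronger inhibition. Compound 2 stands lowest of the three numbers, far from compound 1 and furthest from compound 3, both gaps lying well beyond the usual scatter. Compound 4 `c1ccc(Nc2cncc(N3CC4CC(C3)N4)c2)cc1` has not yet been measured; it differs from compound 2 in one place: hydrogen in place of chloro on an aromatic carbon. For the measured compounds named here, no measured pair isolates this change, since compound 1 and compound 3 differ from each other in two chloro groups and share a different core from compound 2. Going by the values given here, with no step to rest on, a modest shift toward weaker binding seems the more likely outcome, a 4.2-fold higher number from compound 2 to compound 4 (0.63 log units; beyond the scatter) being the expected step. Compound 4 is estimated at 0.5 nM, in a range from 0.1 nM to 3 nM.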

Compound 4, inhibition constant: 0.0807 nM
The estimate for compound 4 lay 6.2-fold (0.79 log units) above the measured number; measured number outside the range, below it.
By their numbers in this assay, from the lowest: compounds 4 and 2 (each within the scatter of the next); then compounds 1 and 3 (each within the scatter of the next).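

In this assay, the change from 4-chlorophenyl to phenyl gives a 1.5-fold lower number from compound 2 to compound 4 (0.17 log units; within the scatter), so on this core the chloro group can give way to hydrogen without a shift that stands clear of the scatter. The earlier compounds shown here held no pair that isolated this position. Nothing measured here offers an explanation for this result. Going by these compounds, whether a methoxy group or a carboxylic acid at the same place would be tolerated remains open, as does whether the same change would read alike on the core of compound 1.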